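The source may hold more compounds than are shown below. What is called first, only, known or untested is meant among the compounds shown, and "the series" means these compounds.

For the measured compounds named here, in a functional assay on NCI60 cells (Homo sapiens) for inhibition (a lower number here means a stronger inhibitor of growth, a higher number a weaker inhibitor of growth), compound 3 `O=C1C=CC(O)(c2cc3ccccc3n2S(=O)(=O)c2ccc(CCC(=O)O)cc2)C=C1` gives 2340 nM, the highest number of the three compounds measured so far. Compound 1 `O=C1C=CC(O)(c2cc3ccc(F)cc3n2S(=O)(=O)c2ccccc2)C=C1` gives 16 nM, and compound 2 `COC(=O)CCc1ccc(S(=O)(=O)n2c(C3(O)C=CC(=O)C=C3)cc3ccc(F)cc32)cc1` gives 500 nM. Compound 4 `O=C1C=CC(O)(c2cc3ccc(F)cc3n2S(=O)(=O)c2ccc(CCC(=O)O)cc2)C=C1` differs from compound 3 by one change, fluoro in place of hydrogen on an aromatic carbon. Going by the values given here, no measured step isolates this change. Among the compounds with values here, the only single-place step available, a 31-fold higher number from compound 1 to compound 2 (1.49 log units; beyond the scatter), is large, but it concerns 2-(methoxycarbonyl)ethyl in place of hydrogen and says nothing direct about fluoro. Compound 2 carries the fluoro group and has a lower number than compound 3, but those two compounds also differ at the end of their chains, so their gap mixes two changes. Only a small shift towards a lower number is therefore expected in this assay, possibly none beyond the scatter. The expected move is a 1.7-fold lower number from compound 3 to compound 4 (0.22 log units; within the scatter). For compound 4 the estimated value is 1400 nM, with an expected range from 400 nM to 4500 nM.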

Compound 4, concentration for 50% growth inhibition: 2500 nM
Compound 4: the middle estimate sits 1.8-fold (0.25 log units) below what was measured; the measured number falls inside the stated range.
By their numbers in this assay, from the lowest: compound 1; then compound 2; then compounds 3 and 4 (each within the scatter of the next).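

In this assay, fluoro in place of hydrogen on an aromatic carbon, meta to a fused ring and para to a fused ring, gives a step within the scatter (a 1.1-fold higher number from compound 3 to compound 4 (0.03 log units; within the scatter)), so with the 2-carboxyethyl group present this change has no readable effect. With fluoro held constant, the chain can now be read on its own: hydrogen in place of methyl on an oxygen next to a carbonyl group gives a modest step (a 5.0-fold higher number from compound 2 to compound 4 (0.70 log units; beyond the scatter)), and 2-carboxyethyl in place of hydrogen gives a large one (a 160-fold higher number from compound 1 to compound 4 (2.19 log units; beyond the scatter)). Nothing measured here explains these steps.

The compounds shown leave open whether fluoro would be equally silent in a compound without the 2-carboxyethyl group. They also leave open how chloro at this aromatic carbon, or an amide at the chain end, would compare.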